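Furan to phenyl on the amide side chain

A few compounds are considered here, and "the series" means these few. Any claim that something is new, unique, unknown or untested is made for them only; others in the source may bear on it.

In a functional assay on SK-BR-3 cells (Homo sapiens) for cytotoxicity, read by MTT assay, with a stated time of 72 h (a higher number here means a weaker inhibitor, a lower number a stronger inhibitor), compound 1 `Nc1ccc(Nc2c(C(=O)NCc3ccc(F)cc3)nc(Br)c3cccnc23)cc1` gives 4000 nM, while compound 2 `N[C@H]1CC[C@H](Nc2c(C(=O)NCc3ccco3)nc(Br)c3cccnc23)CC1` gives 10000 nM, the higher of the two numbers and separated from compound 1 by a gap beyond the scatter. For compound 3 `NCCCNc1c(C(=O)NCc2ccc(F)cc2)nc(Br)c2cccnc12` the result in this assay is "not determined" (no result reported), so no number is reported for it. Compound 4 `N[C@H]1CC[C@H](Nc2c(C(=O)NCc3ccccc3)nc(Br)c3cccnc23)CC1` differs from compound 2 in one place: phenyl in place of furan-2-yl on a saturated chain carbon bound to an amide-type nitrogen. Among the compounds with values here, no comparable step between measured compounds exists, so the direction is uncertain; since compound 1, whose amide also carries a six-membered aromatic ring of carbon only, gives 4000 nM, a modest move toward a lower number is expected, though not one sure to lie beyond the scatter. For compound 4 the estimate in this assay is 7000 nM, with a range from 2500 nM to 20000 nM. The expected step is a 1.4-fold lower number from compound 2 to compound 4 (0.15 log units; within the scatter).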

Compound 4, half-maximal inhibitory concentration: 8000 nM
Compound 4: middle estimate off by 1.1-fold (0.06 log units), on the low side; measured number inside the range.
By their numbers in this assay, from the lowest: compounds 1, 4 and 2 (each within the scatter of the next, the first and the last beyond it).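

In this assay, within the data shown here, the first one-place comparison on a saturated chain carbon bound to an amide-type nitrogen shows a 1.3-fold lower number from compound 2 to compound 4 (0.10 log units; within the scatter) and so does not separate furan-2-yl from phenyl. At this place, a five-membered aromatic ring with 1 hetero atom and a six-membered aromatic ring of carbon only read alike in this series. Nothing at hand explains this result.

Still open, on these data alone, is how a fluoro group on the phenyl of compound 4 would read. As far as these compounds go, a pyridyl ring or a phenethyl group in place of the benzyl also remains untested in these data.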